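This account rests on a few compounds, and the source may have more. Where it says the series, first, only, none or still open, it means among the compounds named here.

Measured in a functional assay on PC-3 cells (Homo sapiens) for cytotoxicity, read by MTT assay, with a stated time of 72 h; on this read-out higher numbers stand for weaker inhibition and lower numbers for stronger inhibition:

- compound 1 `COc1cc(/C=C/C(=O)Nc2cc3c(Nc4ccc(F)c(Cl)c4)ncnc3cc2O[C@H]2CCOC2)cc(OC)c1OC` gives 20500 nM
- compound 2 `COc1ccc(/C=C/C(=O)Nc2cc3c(Nc4ccc(F)c(Cl)c4)ncnc3cc2O[C@H]2CCOC2)c(OC)c1OC` gives 7670 nM
- compound 3 `COc1cc(/C=C/C(=O)Nc2cc3c(Nc4ccc(F)c(Cl)c4)ncnc3cc2O[C@H]2CCOC2)cc(OC)c1` gives 25600 nM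

Compound 3 stands within the scatter of compound 1, while compound 2 lies clearly lower, with a 3.3-fold higher number from compound 2 to compound 3 (0.52 log units; beyond the scatter). Compound 4 `COc1cc(/C=C/C(=O)Nc2cc3c(Nc4ccc(F)c(Cl)c4)ncnc3cc2O[C@H]2CCOC2)cc(OC)c1O` places hydroxy in place of hydrogen on an aromatic carbon of compound 3, ortho to two methoxy groups and para to a large group: hydroxy in place of hydrogen on an aromatic carbon. The closest evidence is a 1.2-fold higher number from compound 1 to compound 3 (0.10 log units; within the scatter), where the same carbon loses methoxy. The modest 2.7-fold lower number from compound 1 to compound 2 (0.43 log units; beyond the scatter) involves a different substitution pattern and bears less directly. No change beyond the scatter is therefore expected in this assay. The expected change is a 1.3-fold lower number from compound 3 to compound 4 (0.11 log units; within the scatter). Compound 4 is estimated at 20000 nM, within an expected range of 8000 nM to 45000 nM.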

Compound 4, half-maximal inhibitory concentration: 26500 nM
Compound 4: the middle estimate sits 1.3-fold (0.12 log units) below what was measured; low and high end bracket the measured number.
By their numbers in this assay, from the lowest: compound 2; then compounds 1, 3 and 4 (each within the scatter of the next).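

In this assay, hydroxy on this aromatic carbon, para to a large group, reads no differently from hydrogen (a 1.0-fold higher number from compound 3 to compound 4 (0.02 log units; within the scatter)) or from methoxy (a 1.3-fold higher number from compound 1 to compound 4 (0.11 log units; within the scatter)). The 4-hydroxy-3,5-dimethoxyphenyl group still stands apart from the 2,3,4-trimethoxyphenyl group of compound 2 (a 3.5-fold higher number from compound 2 to compound 4 (0.54 log units; beyond the scatter)), so swapping hydroxy for methoxy here does not close that gap. Nothing measured here explains this flatness. The compounds shown leave open whether an amine or a carboxylic acid on this carbon would also read the same, and whether hydroxy would matter within the 2,3,4-substituted pattern.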